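This account rests on a few compounds, and the source may have more. Where it says the series, first, only, none or still open, it means among the compounds named here.

Compound 2 `COc1ccc(NC(=O)c2ccc(OCCCN(C)C)c([N+](=O)[O-])c2)cc1` gives 127000 nM in a toxicity assay on Huh-7.5 cells (Homo sapiens) for inhibition, read by MTT assay, with a stated time of 96 h; on this read-out lower numbers stand for higher toxicity in this test and higher numbers for lower toxicity in this test. Compound 1 `CCC(=O)Nc1cc(C(=O)Nc2ccc(N(C)C)cc2)ccc1OC(C)C` gives 80600 nM in this assay, a number within the scatter of that of compound 2. Compound 3 `CC(C)Oc1ccc(C(=O)Nc2ccc(N(C)C)cc2)cc1[N+](=O)[O-]` gives 50000 nM in this assay, and the gap between compound 2 and compound 3 lies beyond the scatter, so compound 2 stands at the less toxic end of the three. Going by the values given here, the only measured step, a 1.6-fold lower number from compound 1 to compound 3 (0.21 log units; within the scatter), concerns a different position and gives no guidance here. Compound 4 `COc1ccc(NC(=O)c2ccc(OCCCCl)c([N+](=O)[O-])c2)cc1` differs from compound 2 by chloro in place of dimethylamino on a saturated chain carbon, three bonds along the chain from an oxygen on an aromatic ring. Among the compounds with values here, no measured step covers this change, so no step beyond the scatter is expected in this assay. The expected step is a 1.3-fold lower number from compound 2 to compound 4 (0.10 log units; within the scatter). For compound 4 the estimate in this assay is 100000 nM, with a range from 40000 nM to 250000 nM.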

Compound 4, half-maximal cytotoxic concentration: 39700 nM
Estimate against measurement, compound 4: 2.5-fold (0.40 log units) above, and the stated range ends above it.
By their numbers in this assay, from the lowest: compounds 4, 3, 1 and 2 (each within the scatter of the next, the first and the last beyond it).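

In this assay, going by these compounds alone, chloro in place of dimethylamino on the saturated chain carbon gives a 3.2-fold lower number from compound 2 to compound 4 (0.51 log units; beyond the scatter), the only step at this position, and it lies beyond the scatter. Within the data shown here, the chain end therefore affects toxicity in this test, which the earlier compounds, whose one step lay elsewhere and within the scatter, could not show. No measurement here gives a cause for the step.

On these data alone, whether the change follows the loss of dimethylamino or the arrival of chloro remains open. A hydroxyl, a morpholine or a longer chain could separate the two.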